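A few compounds are considered here, and "the series" means these few. Any claim that something is new, unique, unknown or untested is made for them only; others in the source may bear on it.

Measured compounds:
- compound 1 `COc1ccc(S(=O)(=O)N2CCc3cccc(-c4ccc(F)cc4)c32)cc1` gives 79 nM in a functional assay on MKN-45 cells (Homo sapiens) for inhibition, with a stated time of 72 h; on this read-out lower numbers stand for stronger inhibition and higher numbers for weaker inhibition
- compound 2 `COc1ccc(S(=O)(=O)N2CCc3cccc(-c4ccc(C#N)cc4)c32)cc1` gives 17.2 nM in this assay
- compound 3 `COc1ccc(S(=O)(=O)n2ccc3cccc(-c4ccc(F)cc4)c32)cc1` gives 170 nM in this assay

Among these three, compound 2 has the lowest number: its nearest neighbour is compound 1, and compound 3 is furthest away, both with higher numbers that lie beyond the scatter, so compound 2 stands as the most potent of the measured set.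

The step now followed leads from compound 2 to compound 4 `COc1ccc(S(=O)(=O)N2CCc3cccc(-c4ccc(F)c(F)c4)c32)cc1`, not yet tested in this assay. The change is 3,4-difluorophenyl in place of 4-cyanophenyl on an aromatic carbon. Within the data shown here, one measured step bears directly on it: a 4.6-fold lower number from compound 1 to compound 2 (0.66 log units; beyond the scatter). That step shows that exchanging fluoro for cyano at this position lowered the number by a modest but clear amount. Among the measured compounds shown here, compound 4 undoes that exchange, returning a fluoro to the ring and adding a second one; no measured pair shows what the second fluoro does on its own.

Compound 4 is therefore expected to sit near compound 1 rather than compound 2, with a higher number than compound 2 by roughly a 3.5-fold higher number from compound 2 to compound 4 (0.54 log units; beyond the scatter). The estimate for compound 4 in this assay is 60 nM, within a range from 25 nM to 150 nM.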

Compound 4, half-maximal inhibitory concentration: 55.5 nM
The estimate for compound 4 lay 1.1-fold (0.03 log units) above the measured number, within the range that was stated.
By their numbers in this assay, from the lowest: compound 2; then compounds 4 and 1 (each within the scatter of the next); then compound 3.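

Replacing 4-cyanophenyl with 3,4-difluorophenyl in this assay gives a 3.2-fold higher number from compound 2 to compound 4 (0.51 log units; beyond the scatter) and so shows that a ring carrying two fluoro groups does not match the nitrile-bearing ring at this position. Among these compounds, the new compound also gives the first direct reading of a second fluoro here, in place of hydrogen on an aromatic carbon: a 1.4-fold lower number from compound 1 to compound 4 (0.15 log units; within the scatter) means that, in this assay, the second fluoro produces no difference that can be separated from ordinary variation between repeated measurements. Among these three compounds, the advantage therefore stays with the 4-cyanophenyl group of compound 2, while the monofluoro and difluoro rings cannot be told apart, and no measurement is available to explain either result.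

The compounds shown leave open how the 4-cyanophenyl group would compare with rings carrying other groups at this position, such as an amine, a carboxylic acid or a methoxy group. They also leave open whether the 4-cyanophenyl group would keep its advantage on the core of compound 3, where only the 4-fluorophenyl version is shown.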